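Swapping the carbamate oxygen and oxetane for a thiocarbamate

The source may hold more compounds than are shown below. What is called first, only, known or untested is meant among the compounds shown, and "the series" means these compounds.

The shared core carries a piperidine whose nitrogen bears a carbonyl-linked side group, and two compounds with different side groups have been measured in a functional assay on isolated protein for inhibition of Glucose-dependent insulinotropic receptor (Rattus norvegicus), read by HTRF and cAMP accumulation; on this read-out higher numbers stand for an effect only at larger amounts of compound and lower numbers for an effect already at smaller amounts. Compound 1 `Cc1nc(S(C)(=O)=O)ccc1Oc1ncnc(OC2CCN(C(=O)O[C@H](C)C(F)(F)F)CC2)c1F` gives 110 nM. Compound 2 `Cc1nc(S(C)(=O)=O)ccc1Oc1ncnc(OC2CCN(C(=O)OC3(C(F)(F)F)COC3)CC2)c1F` gives 342 nM, which is the higher of the two numbers; the step of a 3.1-fold higher number from compound 1 to compound 2 (0.49 log units; beyond the scatter) shows that the 3-(trifluoromethyl)oxetan-3-yl group weakened the effect relative to the 1-(trifluoromethyl)ethyl group.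

Compound 3 `Cc1nc(S(C)(=O)=O)ccc1Oc1ncnc(OC2CCN(C(=O)SC3(C)CC3)CC2)c1F` changes the same part of the molecule again: a group of 5 heavy atoms (4 carbon, 1 sulfur; one three-membered non-aromatic ring of carbon only) in place of a group of 9 heavy atoms (4 carbon, 2 oxygen, 3 fluorine; one four-membered non-aromatic ring with 1 hetero atom), on a carbonyl carbon. Going by the values given here, no measured step covers a sulfur in place of an oxygen on this carbonyl carbon, so the only guidance is indirect. The step from compound 1 to compound 2 suggests that a smaller group on this carbonyl carbon goes with a lower number in this assay, and compound 3 returns to a small branched group, albeit one without fluorine and attached through sulfur. Compound 3 is therefore expected to move back toward compound 1, giving an estimated 1.7-fold lower number from compound 2 to compound 3 (0.23 log units; within the scatter). The estimate for compound 3 in this assay is 200 nM, with a plausible range from 60 nM to 700 nM, the width reflecting the untested sulfur-for-oxygen exchange.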

Compound 3, half-maximal effective concentration: 166 nM
For compound 3 the middle estimate is 1.2-fold (0.08 log units) above the measured one; the range from low to high includes it.
By their numbers in this assay, from the lowest: compounds 1 and 3 (each within the scatter of the next); then compound 2.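

In this assay, a group with a sulfur on the carbonyl carbon and no fluorine at all gives a 2.1-fold lower number from compound 2 to compound 3 (0.31 log units; beyond the scatter) and stands level with the fluorinated group of compound 1, as a 1.5-fold higher number from compound 1 to compound 3 (0.18 log units; within the scatter) shows. This position therefore accepts more than one kind of group, and among these three compounds, fluorine in the side group is not required to reach the level of compound 1. Because the linking atom, the ring and the fluorine all differ at once between these compounds, the steps cannot assign the shift to any one of these features, and no measurement shown offers a reason for it.

From the compounds shown here alone, what remains open is the effect of the sulfur alone, which would take a matched pair such as the same three-membered carbon ring attached through oxygen, or the 1-(trifluoromethyl)ethyl group attached through sulfur. Going by these compounds, it is also open how this position responds to an amine nitrogen on the carbonyl carbon in place of the oxygen or sulfur, or to a longer carbon chain in place of the small branched groups.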